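From 4-fluorophenyl to 4-bromophenyl on the shared core

This account rests on a few compounds, and the source may have more. Where it says the series, first, only, none or still open, it means among the compounds named here.

In an ADME assay on L02 cells (Homo sapiens) for cytotoxicity, read by MTT assay, with a stated time of 24 h (a lower number here means a stronger inhibitor, a higher number a weaker inhibitor), compound 1 `CN1C/C(=C\c2ccc(Cl)cc2)C(=O)/C(=C/c2cccc([N+](=O)[O-])c2)C1` gives > 20000 nM, which is a limit of the assay and not a number.

Among the compounds with values here, compound 2 `CN1C/C(=C\c2ccc(F)cc2)C(=O)/C(=C/c2ccc(C#N)cc2)C1` gives 20900 nM, the only numeric value so far, so its standing cannot yet be set against a second number.

Compound 3 `CN1C/C(=C\c2ccc(Br)cc2)C(=O)/C(=C/c2ccc(C#N)cc2)C1` is the next to be read. It carries bromo in place of fluoro on an aromatic carbon, para to a large group, giving the change from 4-fluorophenyl to 4-bromophenyl: bromo in place of fluoro on an aromatic carbon.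

Within the data shown here, the series offers no step between measured compounds to size this change. In this assay, no shift beyond the scatter is expected in either direction, and the estimate is anchored on compound 2 at 20900 nM.

The expected 1.1-fold lower number from compound 2 to compound 3 (0.04 log units; within the scatter) is small.

For compound 3, the estimated value is 19000 nM, with an expected range of 9000 nM to 40000 nM.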

Compound 3, half-maximal inhibitory concentration: 10500 nM
For compound 3 the middle estimate is 1.8-fold (0.26 log units) above the measured one; the range from low to high includes it.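

In this assay, within the data shown here, bromo in place of fluoro on an aromatic carbon, para to a large group, gives a 2.0-fold lower number from compound 2 to compound 3 (0.30 log units; within the scatter), the first step that can be sized. With the rest of the molecule held constant, this exchange of one halogen for another does not separate compound 2 from compound 3 in this assay. The series now has two numbers to read, with compound 2 at 20900 nM and compound 3 at 10500 nM.

Going by these compounds, whether an amine or a carboxylic acid at this position would move the number beyond the scatter stays open. Compound 1 gives > 20000 nM, a limit of the assay and not a number, so it sizes no step here: the limit of > 20000 nM in this assay, at which 1 of the 3 values shown sits.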